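A few compounds are considered here, and "the series" means these few. Any claim that something is new, unique, unknown or untested is made for them only; others in the source may bear on it.

Series notes. Compound 1 `COc1ccc(-c2coc3cc(OCCCSC(=S)N4CCOCC4)ccc3c2=O)cc1` is measured in a functional assay on PC-3 cells (Homo sapiens) for inhibition, read by MTT assay, with a stated time of 48 h (on this read-out lower numbers stand for stronger inhibition and higher numbers for weaker inhibition), and gives 27400 nM, the highest of the three numbers at hand. Compound 2 `COc1ccc(-c2coc3cc(OCCCCSC(=S)N4CCN(C(=O)OC(C)(C)C)CC4)ccc3c2=O)cc1` gives 4610 nM in this assay, and compound 3 `COc1ccc(-c2coc3cc(OCCSC(=S)N4CCN(C(=O)OC(C)(C)C)CC4)ccc3c2=O)cc1` gives 3640 nM; both stand beyond the scatter below compound 1, and neither differs from compound 1 in one place only. Compound 4 `COc1ccc(-c2coc3cc(OCCCSC(=S)N4CCN(C)CC4)ccc3c2=O)cc1` is not yet measured. It differs from compound 1 by 4-methylpiperazin-1-yl in place of morpholin-4-yl on a thiocarbonyl carbon. For the measured compounds named here, no measured step matches this change. The step from compound 1 to compound 4 is expected to lower the number, since compound 2 gives 4610 nM and compound 3 gives 3640 nM, both bearing a piperazine ring in that place, so an estimated 3.0-fold lower number from compound 1 to compound 4 (0.48 log units; beyond the scatter) is taken. Compound 4 is estimated at 9000 nM, with a range from 3000 nM to 27000 nM.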

Compound 4, half-maximal inhibitory concentration: 2210 nM
The estimate for compound 4 lay 4.1-fold (0.61 log units) above the measured number, outside the stated range (below it).
By their numbers in this assay, from the lowest: compounds 4, 3 and 2 (each within the scatter of the next, the first and the last beyond it); then compound 1.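

In this assay, 4-methylpiperazin-1-yl in place of morpholin-4-yl on a thiocarbonyl carbon gives a 12-fold lower number from compound 1 to compound 4 (1.09 log units; beyond the scatter), with the chain and the core of compound 1 unchanged. For the compounds shown here, this is the first reading of this position alone, since the earlier compounds differed from compound 1 in more than one place, and it shows that the read-out responds strongly to this ring exchange. No available evidence accounts for the size of the step. Open, as far as these compounds go, are how an unsubstituted piperazine or a piperidine would read here, and whether the step holds on a longer chain.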